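A few compounds are considered here, and "the series" means these few. Any claim that something is new, unique, unknown or untested is made for them only; others in the source may bear on it.

For the measured compounds named here, in a physicochemical assay for lipophilicity, measured as octanol-water partition, at pH 7.4 (on this read-out higher numbers stand for higher lipophilicity and lower numbers for lower lipophilicity), compound 1 `Cc1ccc(Cn2c(=O)[nH]c3c(N)nc(C(F)(F)F)cc32)cn1` gives 2.3 and compound 2 `Cc1nc(Cn2c(=O)[nH]c3c(N)nc(C(F)(F)F)cc32)cs1` gives 2.3 and so stands level with compound 1, its only measured neighbour. Compound 3 `Cc1nc(Cn2c(=O)[nH]c3c(N)nc(C(F)(F)F)cc32)co1` shares the core of compound 2 and carries 2-methyl-1,3-oxazol-4-yl in place of 2-methyl-1,3-thiazol-4-yl on a saturated chain carbon bound to an aromatic nitrogen. Going by the values given here, only one measured step bears on this change: no change at the digits printed from compound 1 to compound 2 (within the scatter) where 2-methyl-1,3-thiazol-4-yl replaced 6-methylpyridin-3-yl at the same place. Among the compounds with values here, that step involves a different pair of rings, so it shows only that one ring exchange here left the read-out level. Within the data shown here, no measured pair isolates the exchange of sulfur for oxygen, and a single case sets no rule. A modest fall in this assay is nevertheless expected, with a wide margin as nothing measured yet tests it. The expected step is a number 0.50 log units lower from compound 2 to compound 3 (beyond the scatter) and would lie somewhat beyond the usual scatter. For compound 3 the estimate is 1.8 (expected range 1.4 to 2.2).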

Compound 3, distribution coefficient: 1.7
Beside the measured number, compound 3's estimate is 0.10 log units above it; low and high end bracket the measured number.
By their numbers in this assay, from the lowest: compound 3; then compounds 1 and 2 (each within the scatter of the next).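

The oxazole result shows that this place on the saturated chain carbon bound to an aromatic nitrogen is not indifferent to the ring it carries: in this assay there is a number 0.60 log units lower from compound 2 to compound 3 (beyond the scatter), even though 2-methyl-1,3-oxazol-4-yl and 2-methyl-1,3-thiazol-4-yl match in ring size and in their counts of heavy atoms, hydrogen-bond donors and hydrogen-bond acceptors, and differ by oxygen in place of sulfur. Set against 6-methylpyridin-3-yl, the oxazole ring gives a number 0.60 log units lower from compound 1 to compound 3 (beyond the scatter), so the level result from the earlier ring exchange does not extend to every ring tried here. Nothing at hand explains the fall in this assay, and no independent measurement bears on this change.

As far as these compounds go, this is a single pair on a single core, so it remains open whether oxygen in place of sulfur would give a step of similar size with other substituents or on another core. Also open, from the compounds shown here alone, is how this assay would respond at this place to a plain phenyl ring, to a ring bearing a primary amine, or to a longer chain between the ring and the aromatic nitrogen.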